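The compounds below may be only part of what the source reports. "The series", "measured", "known", "first", "only" and "open" are said of these compounds alone.

Compound 1 `N#CC1CN1C(=O)Nc1ccc(Cl)c(Cl)c1`: 14000 nM
Compound 2 `CCCCNC(=O)N1CC1C#N`: 18000 nM

Of the compounds shown here, two have been measured so far, and both are weak. In a functional assay on WiDr cells (Homo sapiens) for inhibition (on this read-out higher numbers stand for weaker inhibition and lower numbers for stronger inhibition), compound 1 gives 14000 nM and compound 2 gives 18000 nM. Compound 2 stands at one end of these two numbers, but its gap to compound 1 is within the usual scatter of repeated measurements, so the two cannot be told apart on this evidence. Among the measured compounds shown here, the two structures also differ in more than one place, so no single step can be drawn between them.

Compound 3 `CC(C)(C)NC(=O)N1CC1C#N` has not yet been measured. It differs from compound 2 in one place only: tert-butyl in place of butyl on an amide-type nitrogen. The same atoms are present, merely joined differently, and nothing is added or removed in the way of rings, hydrogen-bond donors, hydrogen-bond acceptors or charge. For the measured compounds named here, with no measured step of this kind to lean on, the expectation is a step from compound 2 to compound 3 of no more than the scatter, if anything a slight weakening: a 1.1-fold higher number from compound 2 to compound 3 (0.05 log units; within the scatter). Compound 3 is therefore estimated at 20000 nM in this assay, with a range from 7000 nM to 60000 nM.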

Compound 3, half-maximal inhibitory concentration: > 300000 nM
Compound 3 gave a limit, no number (the forecaster's own chance of this, stated with the estimate: 15%); middle value at least 15-fold (1.17 log units) away from the limit.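

In this assay, putting tert-butyl in place of butyl on an amide-type nitrogen gives an at least 16-fold higher number from compound 2 to compound 3 (1.22 log units; beyond the scatter), so this is a large step. Among the compounds shown here, it shows that this position can tell apart two groups with the same count of carbon atoms, no ring, no hydrogen-bond donors or acceptors and no net charge, a sensitivity that compounds 1 and 2 could not reveal, as no single step could be drawn between them. The reading for compound 3 is a limit of the assay and not a number: the limit of > 300000 nM in this assay, at which 1 of the 3 values shown sits.

From the compounds shown here alone, what remains open is how much branching this position tolerates, since a single step cannot show whether a less branched group such as isopropyl, or a longer chain such as hexyl, would read like compound 2 or like compound 3. Also open, going by these compounds, is whether the same exchange would have a similar effect in another assay or on a different core.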